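This account rests on a few compounds, and the source may have more. Where it says the series, first, only, none or still open, it means among the compounds named here.

The measured compounds, each with its result in a functional assay on HeLa cells (Homo sapiens) for inhibition, read by colorimetric assay, with a stated time of 72 h; a higher number here means that more compound is needed for the effect, a lower number that less compound is needed:

Compound 1, `COC(=O)Cn1nc2c(n1)C(=O)C(C)=C(C)C2=O`: in this assay compound 1 gives 1 ug/mL.
Compound 3, `CC1=C(C)C(=O)c2nn(Cc3ccccc3)nc2C1=O`: in this assay compound 3 gives 0.8 ug/mL.
Compound 2, `COC(=O)C(C)n1n[n+]([O-])c2cc(C)c(C)cc21`: in this assay compound 2 gives only a limit, > 100 ug/mL.

Compound 2 therefore stands apart from the other two: its result is not a number but the limit of the assay, (the limit of > 100 ug/mL in this assay, at which 1 of the 3 values shown sits), while compound 1 and compound 3 both gave numbers well away from that limit. Compound 4, `Cc1cc2c(cc1C)[n+]([O-])nn2C`, is built on the core of compound 2 and differs from it by methyl in place of 1-(methoxycarbonyl)ethyl on an aromatic nitrogen.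

Within the data shown here, only one measured step exists, a 1.3-fold lower number from compound 1 to compound 3 (0.10 log units; within the scatter), and it lies within the scatter. That step swaps the group on the saturated chain carbon bound to an aromatic nitrogen, but on the core of compound 1, which is not the core of compound 2, so it bears on the present change only loosely. Among the measured compounds shown here, no measured step on the core of compound 2 exists.

For the measured compounds named here, compound 2 sits at a limit, and the one step that exists shows a change of the nitrogen substituent leaving the value unchanged, so compound 4 is expected to sit near the limit as well. The estimate for compound 4 in this assay is 100 ug/mL, with a range from 30 ug/mL to 300 ug/mL. The expected step is a number no higher from compound 2 to compound 4 (the limit leaves the size open), none beyond the scatter.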

Compound 4, concentration for half-maximal effect: > 100 ug/mL
Compound 4: a limit, no number (the forecaster's own chance of this, stated with the estimate: 75%); the middle value sits exactly at the limit.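

Compound 2 and compound 4 both give a limit and not a number, so no step can be read between them: the limit of > 100 ug/mL in this assay, at which 2 of the 4 values shown sit. The compounds shown leave open how much methyl in place of 1-(methoxycarbonyl)ethyl on the aromatic nitrogen changes the result on the core of compound 2, and in which direction.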